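Methoxy added to the dimethoxyphenyl arm of compound 2

A few compounds are considered here, and "the series" means these few. Any claim that something is new, unique, unknown or untested is made for them only; others in the source may bear on it.

Of the compounds shown here, three have been measured in a functional assay on HSC-3 cells (Homo sapiens) for cytotoxicity; a lower number here means that less compound is tolerated, a higher number that more compound is tolerated. Compound 1 `COc1cc(/C=C2\Cc3ccccc3/C(=C\c3ccc([N+](=O)[O-])cc3)C2=O)cc(OC)c1OC` gives 2900 nM. Compound 2 `COc1ccc(/C=C2\CCC/C(=C\c3ccc([N+](=O)[O-])cc3)C2=O)cc1OC` gives 4400 nM, and compound 3 `COc1ccc(/C=C2\Cc3ccccc3/C(=C\c3ccc([N+](=O)[O-])cc3)C2=O)cc1OC` gives 4200 nM. Compound 3 and compound 1 differ in one place, (methoxy in place of hydrogen on an aromatic carbon), and the step of a 1.4-fold lower number from compound 3 to compound 1 (0.16 log units; within the scatter) falls within the scatter. Compound 2 and compound 3 share the same substituents but rest on different cores; the difference between the two cores is not broken down here, and their two values lie within the scatter of each other.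

Compound 4 `COc1cc(/C=C2\CCC/C(=C\c3ccc([N+](=O)[O-])cc3)C2=O)cc(OC)c1OC` is not yet measured. It differs from compound 2 by methoxy in place of hydrogen on an aromatic carbon, the same change that turns compound 3 into compound 1, made on the core of compound 2 instead. For the measured compounds named here, because the earlier step of a 1.4-fold lower number from compound 3 to compound 1 (0.16 log units; within the scatter) stayed within the scatter, a step of similar size, a 1.4-fold lower number from compound 2 to compound 4 (0.14 log units; within the scatter), is expected here, resting on the single precedent and on compound 2 giving 4400 nM. Compound 4 is therefore estimated at 3200 nM, with a range of 1500 nM to 6500 nM.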

Compound 4, half-maximal cytotoxic concentration: 4700 nM
Compound 4: middle estimate off by 1.5-fold (0.17 log units), on the low side, within the range that was stated.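

In this assay, the methoxy placed on the core of compound 2 gives a 1.1-fold higher number from compound 2 to compound 4 (0.03 log units; within the scatter), so on this core as well the step stays inside the usual scatter. Set beside the earlier step on the other core, the two steps do not separate from each other: the same change on two cores in this assay, a 1.4-fold lower number (0.16 log units; within the scatter) from compound 3 to compound 1 and a 1.1-fold higher number (0.03 log units; within the scatter) from compound 2 to compound 4, 1.5-fold (0.19 log units) apart, within the scatter of two such steps. This shows that, for these two pairs alone, the change can be carried from one core to the other without any step beyond the scatter, but it does not show that the change acts alike on the two cores, and two pairs of steps this small give no rule for any further core.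

The compounds shown leave open what an amine, a carboxylic acid or a longer alkoxy chain in place of this methoxy would give in this assay. They also leave open whether a group other than methoxy would give steps that differ between the two cores.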